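This account rests on a few compounds, and the source may have more. Where it says the series, first, only, none or still open, it means among the compounds named here.

Three compounds were measured in a functional assay on MCF7 cells (Homo sapiens) for inhibition, read by sulforhodamine B assay, with a stated time of 72 h; on this read-out higher numbers stand for weaker inhibition and lower numbers for stronger inhibition:

Compound 1 `CC(c1ccc(-c2ccccc2)c(F)c1)c1nnc2n1N=C(c1ccc(OC(F)(F)F)cc1)CS2`: 4800 nM
Compound 2 `COc1ccc(C2=Nn3c(nnc3C(C)c3ccc(-c4ccccc4)c(F)c3)SC2)cc1`: 2600 nM
Compound 3 `CC(C)Cc1ccc(C(C)c2nnc3n2N=C(c2ccc(OC(F)(F)F)cc2)CS3)cc1`: 1100 nM

Compound 2 differs from compound 1 by methyl in place of trifluoromethyl on an oxygen on an aromatic ring, and this gave a 1.8-fold lower number from compound 1 to compound 2 (0.27 log units; within the scatter). Compound 3 has a different core from compound 1; the difference between the two cores is not broken down here. Compound 3 has the lowest number of the three, and its steps to compound 2 and to compound 1 lie beyond the scatter.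

Compound 4 `COc1ccc(C2=Nn3c(nnc3C(C)c3ccc(CC(C)C)cc3)SC2)cc1` is not yet measured in this assay. It differs from compound 3 by methyl in place of trifluoromethyl on an oxygen on an aromatic ring, the same change as between compound 1 and compound 2, at a place that reads the same way. The step is expected to be about a 1.6-fold lower number from compound 3 to compound 4 (0.20 log units; within the scatter), resting on the step of a 1.8-fold lower number from compound 1 to compound 2 (0.27 log units; within the scatter). Compound 4 is therefore estimated at 700 nM in this assay, likely between 250 nM and 2000 nM.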

Compound 4, half-maximal inhibitory concentration: 5200 nM
For compound 4 the middle estimate is 7.4-fold (0.87 log units) below the measured one; the measured number lies above the stated range.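

In this assay, the change from trifluoromethoxy to methoxy gave a 4.7-fold higher number from compound 3 to compound 4 (0.67 log units; beyond the scatter), so it did not carry over as one fixed step from the core of compound 1 to the core of compound 3: the same change on two cores in this assay, a 1.8-fold lower number (0.27 log units; within the scatter) from compound 1 to compound 2 and a 4.7-fold higher number (0.67 log units; beyond the scatter) from compound 3 to compound 4, 8.7-fold (0.94 log units) apart, beyond the scatter of two such steps. In these two pairs, the effect of the change therefore depended on the core that carried it. Two pairs do not show why the steps differ, nor do they give a rule for any further core.

The compounds shown leave open how a hydroxyl, an amine or an ethoxy group in place of trifluoromethoxy would read on either core. They also leave open whether such groups would differ between the two cores as methoxy does.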